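A few compounds are considered here, and "the series" means these few. Any claim that something is new, unique, unknown or untested is made for them only; others in the source may bear on it.

Measured in a functional assay on SF-268 cells (Homo sapiens) for antiproliferative activity, read by sulforhodamine B assay, with a stated time of 72 h; a lower number here means a stronger inhibitor, a higher number a weaker inhibitor:
Compound 1, `Cc1ccc(C(/C=C/c2ccc(F)cc2)=N\Nc2nncc3ccccc23)cc1`: 6.5 nM
Compound 2, `NC(=S)NNc1nncc2ccccc12`: 17 nM
Compound 3, `Cc1cc(NS(=O)(=O)c2ccc(Nc3nncc4ccccc34)cc2)no1`: 24 nM

Of these three, compound 3 has the highest number. Its gap to compound 2 lies within the usual scatter of repeat measurements, so no order between those two can be claimed, while its gap to compound 1 lies beyond the scatter. Compound 4, `NS(=O)(=O)c1ccc(Nc2nncc3ccccc23)cc1`, differs from compound 3 in one place: hydrogen in place of 5-methyl-1,2-oxazol-3-yl on a sulfonamide nitrogen. Among the measured compounds shown here, no pair of measured compounds shows this kind of change, so there is no measured step to lean on. The step of a 1.3-fold higher number from compound 3 to compound 4 (0.10 log units; within the scatter) is expected to be small, in either direction, and likely not beyond the scatter. Compound 4 is therefore expected to give about 30 nM, in a range from 10 nM to 90 nM.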

Compound 4, half-maximal inhibitory concentration: 33 nM
Beside the measured number, compound 4's estimate is 1.1-fold (0.04 log units) below it; measured number inside the range.
By their numbers in this assay, from the lowest: compound 1; then compounds 2, 3 and 4 (each within the scatter of the next).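

Hydrogen in place of 5-methyl-1,2-oxazol-3-yl on the sulfonamide nitrogen gives a 1.4-fold higher number from compound 3 to compound 4 (0.14 log units; within the scatter) in this assay and so provides the first measured step at this position. The whole five-membered aromatic ring can therefore leave this nitrogen with no change that can be claimed between this pair. No measurement available here explains this result. The compounds shown leave open how this nitrogen would respond to other groups, such as a methyl, an acetyl or a phenyl ring. This single step cannot predict those replacements.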